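Swapping hydroxy for bromo in a cell tolerance test

The compounds below may be only part of what the source reports. "The series", "measured", "known", "first", "only" and "open" are said of these compounds alone.

Measured in an ADME assay on CHO-K1 cells (Cricetulus griseus) for cytotoxicity, read by MTT assay, with a stated time of 24 h; a lower number here means that less compound is tolerated, a higher number that more compound is tolerated
- compound 1 `Oc1cccc(NC(=S)Nc2ccc3[nH]ccc3c2)c1` gives 977000 nM
- compound 2 `Oc1ccc(NC(=S)Nc2ccc3[nH]ccc3c2)cc1` gives 848000 nM
- compound 3 `OCc1ccc(NC(=S)Nc2ccc3[nH]ccc3c2)cc1` gives 1080000 nM

In this assay compound 2 stands at 848000 nM, within the usual scatter of both compound 1 and compound 3. Compound 4 `S=C(Nc1ccc(Br)cc1)Nc1ccc2[nH]ccc2c1` has bromo in place of hydroxy on an aromatic carbon. Going by the values given here, only one measured step changes this same spot, a 1.3-fold higher number from compound 2 to compound 3 (0.11 log units; within the scatter), and it stays within the scatter. Among the compounds with values here, no measured compound carries bromo, so that step is only an indirect guide. A modest move towards a lower number is expected, with wide uncertainty: a 1.9-fold lower number from compound 2 to compound 4 (0.28 log units; within the scatter). For compound 4 the estimated value is 450000 nM, with an expected range of 100000 nM to 1200000 nM.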

Compound 4, concentration lethal to 50% of the cells: 220000 nM
For compound 4 the middle estimate is 2.0-fold (0.31 log units) above the measured one; the measured number falls inside the stated range.
By their numbers in this assay, from the lowest: compound 4; then compounds 2, 1 and 3 (each within the scatter of the next).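

In this assay this position had shown no change beyond the scatter until bromo replaced hydroxy (a 3.9-fold lower number from compound 2 to compound 4 (0.59 log units; beyond the scatter)) and hydroxymethyl (a 4.9-fold lower number from compound 3 to compound 4 (0.69 log units; beyond the scatter)). The number therefore does respond to what sits at this spot, and less of the bromo compound is tolerated than of either compound it is compared with here. No available evidence explains the shift. As far as these compounds go, it remains open whether chloro, an amine or a carboxylic acid at this spot would lower the number as bromo does, leave it unchanged or raise it.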